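A New Aryl Group on the Ring Nitrogen

This account rests on a few compounds, and the source may have more. Where it says the series, first, only, none or still open, it means among the compounds named here.

compound 1 `N#CC1=C(N)Oc2c(c3nc4ccccc4nc3c3ccccc23)C12C(=O)N(Cc1cnnn1-c1ccc(Br)cc1)c1ccccc12`: in an ADME assay on HUVEC cells (Homo sapiens) for antiproliferative activity, read by MTT assay, with a stated time of 48 h (on this read-out lower numbers stand for stronger inhibition and higher numbers for weaker inhibition), compound 1 reaches only a limit of the assay, > 50000 nM
compound 2 `N#CC1=C(N)Oc2c(c3nc4ccccc4nc3c3ccccc23)C12C(=O)N(Cc1cnnn1-c1cc(Cl)ccc1Cl)c1ccccc12`: in this assay compound 2 likewise reaches only a limit, > 50000 nM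
compound 3 `N#CC1=C(N)Oc2c(N)cc3nc4ccccc4nc3c2C12C(=O)N(Cc1cnnn1-c1ccccc1Br)c1ccccc12`: in this assay compound 3 gives 34200 nM
compound 4 `COc1cc(-n2nncc2CN2C(=O)C3(C(C#N)=C(N)Oc4c(N)cc5nc6ccccc6nc5c43)c3ccccc32)c(OC)cc1Cl`: not yet measured

Among the compounds with values here, compound 3 stands as the only compound of the three with a number rather than a limit, and that number is itself a weak one. The other two values sit at the limit of > 50000 nM in this assay, at which 2 of the 3 values shown sit, so no order among the three can be read.

Compound 4 differs from compound 3 in one place: 4-chloro-2,5-dimethoxyphenyl in place of 2-bromophenyl on an aromatic nitrogen. Within the data shown here, the single step between measured compounds, a step that the two limits leave unreadable from compound 1 to compound 2, also exchanges the aryl group on that aromatic nitrogen, but it runs between two limits and its size cannot be read; moreover compounds 1 and 2 differ from compound 3 in more than this one place. Nothing in the measured data therefore indicates a direction for the change from compound 3 to compound 4.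

The expected step is a 1.2-fold higher number from compound 3 to compound 4 (0.07 log units; within the scatter), which is no more than the usual scatter. Compound 4 is accordingly estimated at 40000 nM in this assay, within 15000 nM to 100000 nM, with a real chance that only a limit is returned.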

Compound 4, half-maximal inhibitory concentration: > 50000 nM
Compound 4 gave a limit, no number (the forecaster's own chance of this, stated with the estimate: 45%); middle value at least 1.2-fold (0.09 log units) away from the limit.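

In this assay, placing 4-chloro-2,5-dimethoxyphenyl where compound 3 carries 2-bromophenyl gives an at least 1.4-fold higher number from compound 3 to compound 4 (0.16 log units; that floor lies within the scatter), so this position now has a step with one measured end, whereas the earlier exchange of aryl groups ran between two limits and cannot be read. Compound 4 returns only a limit of the assay, > 50000 nM, so the step has a floor but no measured size, and a true loss is not established. The entering group has 11 heavy atoms and 2 hydrogen-bond acceptors against 7 heavy atoms and 0 hydrogen-bond acceptors for the leaving group, yet this change yields no new number, and the measured range stays almost closed: the limit of > 50000 nM in this assay, at which 3 of the 4 values shown sit.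

The compounds shown leave open whether any aryl group on this nitrogen can give a clearly lower number than that of compound 3. They also do not tell how an unsubstituted phenyl, a pyridyl ring, or a phenyl bearing an amine or a carboxylic acid would read here, nor how a simple alkyl chain in place of the aryl ring would.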